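A few compounds are considered here, and "the series" means these few. Any claim that something is new, unique, unknown or untested is made for them only; others in the source may bear on it.

Two compounds in this series differ only in one ring substituent. Compound 1 `Cn1c(=O)c2c(nc([S+]([O-])CCc3ccc(Cl)cc3)n2C)n(C)c1=O` carries a chloro group and in an assay on microsomes for inhibition of Amine oxidase [flavin-containing] A (Homo sapiens), read by fluorescence and spectrophotometry, with a stated time of 20 min (on this read-out lower numbers stand for stronger inhibition and higher numbers for weaker inhibition), compound 1 gives 203000 nM. Compound 2 `Cn1c(=O)c2c(nc([S+]([O-])CCc3ccc(Br)cc3)n2C)n(C)c1=O` carries a bromo group instead and gives 57300 nM in this assay. Compound 2 stands as the lowest of the two numbers, with compound 1 the nearest, since a 3.5-fold lower number from compound 1 to compound 2 (0.55 log units; beyond the scatter). Compound 3 `Cn1c(=O)c2c(nc([S+]([O-])CCc3ccc(F)cc3)n2C)n(C)c1=O` has not yet been measured; it differs from compound 2 by fluoro in place of bromo on an aromatic carbon. For the measured compounds named here, the only step that bears on this change is the exchange of chloro for bromo, which moved the number by a 3.5-fold lower number from compound 1 to compound 2 (0.55 log units; beyond the scatter). Compound 3 is therefore expected to run in the opposite direction, with a higher number than compound 2, estimated as a 5.2-fold higher number from compound 2 to compound 3 (0.72 log units; beyond the scatter). For compound 3 the expected value in this assay is 300000 nM, with a range from 100000 nM to 900000 nM.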

Compound 3, half-maximal inhibitory concentration: 239000 nM
The estimate for compound 3 lay 1.3-fold (0.10 log units) above the measured number, within the range that was stated.
By their numbers in this assay, from the lowest: compound 2; then compounds 1 and 3 (each within the scatter of the next).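

At this position, on an aromatic carbon para to a large group, the halogens do not form a graded series in this assay. Bromo stands apart from both other halogens: the lower number seen in a 3.5-fold lower number from compound 1 to compound 2 (0.55 log units; beyond the scatter) is matched by a 4.2-fold higher number from compound 2 to compound 3 (0.62 log units; beyond the scatter), while fluoro and chloro cannot be told apart, with a 1.2-fold higher number from compound 1 to compound 3 (0.07 log units; within the scatter). Nothing available explains why bromo alone differs.

Open, as far as these compounds go, is whether iodo, methyl or methoxy at the same place would give a number close to that of compound 2 or close to those of compound 1 and compound 3. Also open, from the compounds shown here alone, is whether bromo would still stand apart from chloro and fluoro if a longer chain joined the ring to the shared core.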